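Propyl xanthine-type series: hydroxypropyl to ethoxyethyl on the core

The source may hold more compounds than are shown below. What is called first, only, known or untested is meant among the compounds shown, and "the series" means these compounds.

Measured compounds:
compound 1 `CCCn1c(=O)n(CCC(=O)O)c(=O)c2[nH]cnc21`, > 200000 nM
compound 2 `CCCn1c(=O)n(CCC#N)c(=O)c2[nH]cnc21`, 15900 nM
compound 3 `CCCn1c(=O)n(CCCO)c(=O)c2[nH]cnc21`, 12000 nM

In an assay on Cerebral cortex for binding affinity to adenosine receptor A1 (Cavia porcellus), read by radioligand binding (a higher number here means a weaker inhibitor, a lower number a stronger inhibitor), compound 1 reaches only the assay limit (the limit of > 200000 nM in this assay, at which 1 of the 3 values shown sits). Compound 2 gives 15900 nM and compound 3 gives 12000 nM, with a 1.3-fold lower number from compound 2 to compound 3 (0.12 log units; within the scatter). Both steps from the carboxy compound are large: an at least 12-fold lower number from compound 1 to compound 2 (1.09 log units; beyond the scatter) and an at least 16-fold lower number from compound 1 to compound 3 (1.22 log units; beyond the scatter).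

Compound 4 `CCCn1c(=O)n(CCOCC)c(=O)c2[nH]cnc21` differs from compound 3 by ethoxy in place of hydroxymethyl on a saturated chain carbon, two bonds along the chain from an aromatic nitrogen. Going by the values given here, the only step that bears on a neutral group exchange at this place is a 1.3-fold lower number from compound 2 to compound 3 (0.12 log units; within the scatter), which stayed within the scatter. For compound 4 a step of a 1.1-fold higher number from compound 3 to compound 4 (0.03 log units; within the scatter) in this assay is therefore expected, none beyond the scatter. Compound 4 is estimated at 13000 nM, within 4500 nM to 40000 nM.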

Compound 4, inhibition constant: 1900 nM
The estimate for compound 4 lay 6.8-fold (0.84 log units) above the measured number; the measured number lies below the stated range.
By their numbers in this assay, from the lowest: compound 4; then compounds 3 and 2 (each within the scatter of the next). At a limit, above all of these: compound 1.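

Unlike the exchange between nitrile and hydroxymethyl, this position responds beyond the scatter to ethoxy, with a 6.3-fold lower number from compound 3 to compound 4 (0.80 log units; beyond the scatter) and an 8.4-fold lower number from compound 2 to compound 4 (0.92 log units; beyond the scatter) in the ethoxy compound's favour. Compound 1 stands at a limit and not at a number, so an at least 100-fold lower number from compound 1 to compound 4 (2.02 log units; beyond the scatter) gives only a bound: the limit of > 200000 nM in this assay, at which 1 of the 4 values shown sits. The change to 2-ethoxyethyl takes away the hydrogen-bond donor of 3-hydroxypropyl and adds a heavy atom, and these two differences cannot be separated here. Going by these compounds, whether methoxy or a longer chain such as propoxy goes further stays open, as does how an amine at this place compares.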